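Lengthening the Alkyl Tail of an Aminopropyl Oxadiazole

The source may report more compounds than this note shows. Statements on the series, on what has been measured and on what is new or still open speak of the compounds shown alone.

Measured compounds:
- Compound 1, `CCCCCCCCCCc1ccc(-c2noc(CC3CCNC3)n2)cc1`: 44%
- Compound 2, `CCCCCCCCCCc1ccc(-c2noc(CC[C@@H](N)C(=O)O)n2)cc1`: 5%
- Compound 3, `CCCCCCc1ccc(-c2noc(CCCN)n2)cc1`: 55%

All three compounds were tested in an assay on HeLa cells for inhibition of sphingosine-1-phosphate transporter SPNS2 (Mus musculus), read by LC-MS, tested at 2 uM; on this read-out lower numbers stand for less inhibition and higher numbers for more inhibition at the one concentration tested (going by the name of the read-out). Compound 3 gives the highest number of the three; compound 1 sits below it by more than the scatter and compound 2 far below, so on this read-out compound 3 inhibits most. Within the data shown here, the one directly comparable step, a number 39 percentage points lower from compound 1 to compound 2 (beyond the scatter), shows that changing the amine-bearing end of the molecule can move the read-out a long way.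

Compound 4, `CCCCCCCCCc1ccc(-c2noc(CCCN)n2)cc1`, is not yet measured. It differs from compound 3 only in the hydrocarbon tail: propyl in place of hydrogen on a saturated chain carbon, six bonds along the chain from an aromatic carbon. Among the measured compounds shown here, no measured pair isolates a change of tail length alone; compounds 1 and 2 carry a longer tail than compound 3 but also a different end group, so their values do not speak to this step. With nothing in the data bearing on it, the expected step of no change at the digits printed from compound 3 to compound 4 (within the scatter) is small, and no change beyond the scatter is assumed. Compound 4 is therefore estimated at 55%, with a range from 35% to 75%.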

Compound 4, a percentage reported as inhibition, at one concentration (the size of the read-out at that concentration, not a potency): 61%
Beside the measured number, compound 4's estimate is 6 percentage points below it; low and high end bracket the measured number.
By their numbers in this assay, from the lowest: compound 2; then compound 1; then compounds 3 and 4 (each within the scatter of the next).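

In this assay, among these compounds, the pair of compound 3 and compound 4 is the first to vary the tail alone while the aminopropyl end stays fixed, and the step is a number 6 percentage points higher from compound 3 to compound 4 (within the scatter). On this read-out the two compounds cannot be told apart, so this chain carbon, six bonds along the chain from an aromatic carbon, accepts propyl in place of hydrogen without a measurable loss of inhibition, whereas the change at the amine-bearing end, a number 39 percentage points lower from compound 1 to compound 2 (beyond the scatter), moved the number well beyond the scatter. Nothing available here explains the result at the level of mechanism.

This one pair cannot show how far the tail can be extended, so a longer chain such as dodecyl on the same aminopropyl end remains an open question, as does a much shorter chain such as butyl. It also leaves open whether an ether oxygen within the tail, or a phenyl ring at its far end, would be accepted as readily as the added propyl.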